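A few compounds are considered here, and "the series" means these few. Any claim that something is new, unique, unknown or untested is made for them only; others in the source may bear on it.

Compound 1, `CC1=C(C(=O)OC(C)(C)C)C(c2ccoc2)NC(=O)N1`, gives 2% in an assay on membranes from HeLa cells for displacement of a labelled ligand from adenosine receptor A3 (Homo sapiens), read by scintillation counting, with a stated time of 180 min, tested at 1 uM; on this read-out lower numbers stand for less inhibition and higher numbers for more inhibition at the one concentration tested (going by the name of the read-out).
Compound 2, `CC1=C(C(=O)OC(C)(C)C)C(c2cccs2)NC(=O)N1`, gives 7% in this assay.
Compound 3, `CCCOC(=O)C1=C(C)NC(=O)NC1c1ccsc1`, gives 6% in this assay.

All three compounds share one core and differ only in the ring on the saturated ring carbon or in the ester group. Their readings are all small: compound 3 sits with 6%, and its distances to compound 2 and to compound 1 both fall inside the usual scatter, so no real difference between the three can be claimed.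

Compound 4, `CC1=C(C(=O)OC(C)(C)C)C(c2ccsc2)NC(=O)N1`, has not yet been measured. It differs from compound 3 in one place: tert-butyl in place of propyl on an oxygen next to a carbonyl group. For the measured compounds named here, no measured pair shows this change. Going by the values given here, the only measured step, a number 5 percentage points higher from compound 1 to compound 2 (within the scatter), concerns a different place, the ring on the saturated ring carbon, and lies within the scatter. It therefore gives no hint that swapping the alkyl group of the ester would move the reading, and the three measured compounds together show this core giving low readings whatever the variation. For compound 4 the expected step in this assay is no change at the digits printed from compound 3 to compound 4 (within the scatter), that is, none beyond the scatter. Compound 4 is thus estimated at 6%, with a range from -5% to 17%.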

Compound 4, a percentage reported as inhibition, at one concentration (the size of the read-out at that concentration, not a potency): 1%
For compound 4 the middle estimate is 5 percentage points above the measured one; low and high end bracket the measured number.
By their numbers in this assay, from the lowest: compounds 4, 1, 3 and 2 (each within the scatter of the next).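

For the compounds shown here, this is the first measured change at the ester: tert-butyl in place of propyl on an oxygen next to a carbonyl group gives a number 5 percentage points lower from compound 3 to compound 4 (within the scatter) in this assay, so this swap of one small carbon group for another cannot be told apart from no change. The new compound also extends the comparison of rings on the saturated ring carbon: thiophen-3-yl in place of thiophen-2-yl gives a number 6 percentage points lower from compound 2 to compound 4 (within the scatter) and thiophen-3-yl in place of furan-3-yl gives a number 1 percentage points lower from compound 1 to compound 4 (within the scatter), so none of these three rings stands apart from the others when the ester is tert-butyl. Nothing measured on these compounds offers a reason for these readings.

Still open, on these data alone, is whether a longer chain on the ester oxygen, a carboxylic acid in place of the ester, or a phenyl ring or an amine-bearing group on the saturated ring carbon would give a reading beyond the scatter. With readings at a single concentration only, the compounds also leave open how any of them would behave at higher concentrations.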